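A Methylpyridyl Amide After a Parent Known Only as a Limit

The source may report more compounds than this note shows. Statements on the series, on what has been measured and on what is new or still open speak of the compounds shown alone.

Compound 1 `O=C(Nc1nnc(-c2ccc3c(c2)OCCO3)s1)c1ccccc1` — in a functional assay on SW 1116 cells (Homo sapiens) for antiproliferative activity, read by MTT assay, with a stated time of 48 h (on this read-out lower numbers stand for an effect already at smaller amounts and higher numbers for an effect only at larger amounts of compound), compound 1 gives 67.6 ug/mL.
Compound 2 `O=C(Nc1nnc(-c2ccc3c(c2)OCCO3)s1)c1ccncc1` — in this assay compound 2 reaches only a limit, > 100 ug/mL.

Compound 1 and compound 2 share one core and differ only in the group on the carbonyl carbon. The number for compound 2 is a boundary of this assay and not a measured value. Accordingly the step of an at least 1.4-fold higher number from compound 1 to compound 2 (0.17 log units; that floor lies within the scatter) is known only as a floor, and that floor sits inside the usual scatter (the limit of > 100 ug/mL in this assay, at which 1 of the 2 values shown sits).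

Compound 3 `Cc1ccc(C(=O)Nc2nnc(-c3ccc4c(c3)OCCO4)s2)cn1` is the next member. Relative to compound 2 the change is 6-methylpyridin-3-yl in place of pyridin-4-yl on a carbonyl carbon. Among the measured compounds shown here, the only measured step that touches this position, an at least 1.4-fold higher number from compound 1 to compound 2 (0.17 log units; that floor lies within the scatter), is a floor within the scatter and therefore says little about how large a move among pyridyl groups might be. With compound 2 standing only at a limit, the expected step that the limit leaves unreadable from compound 2 to compound 3 is set near no change and carries wide uncertainty. Compound 3 is expected to give about 110 ug/mL in this assay, with a range from 40 ug/mL to 300 ug/mL, and a limit rather than a number would not be surprising.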

Compound 3, half-maximal effective concentration: > 100 ug/mL
Compound 3: no number, only a limit (the forecaster's own chance of this, stated with the estimate: 55%); the middle value lies beyond the limit too.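

The new compound shows that a second pyridyl group on the carbonyl carbon, 6-methylpyridin-3-yl, also ends at a limit and not at a number, so the boundary of this assay now holds more of this small series: the limit of > 100 ug/mL in this assay, at which 2 of the 3 values shown sit.

Against phenyl, the only group here with a measured number, the change gives an at least 1.4-fold higher number from compound 1 to compound 3 (0.17 log units; that floor lies within the scatter); like the earlier floor for pyridin-4-yl, this one does not separate the pyridyl group from phenyl. The step between the two pyridyl groups cannot be read, as both ends of it are limits, so nothing can be said about the exchange of pyridin-4-yl for 6-methylpyridin-3-yl itself.

Going by these compounds, whether either pyridyl group truly lies apart from phenyl remains open, as does the true size of any of these steps. Also open, on these data alone, is how the number of compound 1 would move if its phenyl carried an amine or a carboxylic acid, or if a longer chain such as benzyl stood on the carbonyl carbon in its place.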